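Para Halogen Swap on a Weak Monoamine Oxidase A Inhibitor

This account rests on a few compounds, and the source may have more. Where it says the series, first, only, none or still open, it means among the compounds named here.

Of the compounds shown here, two sharing one core have been measured in an assay on cells for inhibition of Amine oxidase [flavin-containing] A (Homo sapiens), read by fluorescence and spectrophotometry, using microsomes, with a stated time of 20 min; a lower number here means a stronger inhibitor, a higher number a weaker inhibitor. Compound 1, `N#Cc1ccc(-c2nnc(-c3ccc(S(N)(=O)=O)cc3)o2)cc1`, carries a nitrile on its outer ring and in this assay gives 24300 nM. Compound 2, `NS(=O)(=O)c1ccc(-c2nnc(-c3ccc(Cl)cc3)o2)cc1`, carries a chloro at the same spot and gives 68000 nM. For the measured compounds named here, compound 2 thus stands at the higher, weaker end of the two numbers available; the only step recorded, a 2.8-fold higher number from compound 1 to compound 2 (0.45 log units; beyond the scatter), separates it from compound 1.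

Compound 3, `NS(=O)(=O)c1ccc(-c2nnc(-c3ccc(F)cc3)o2)cc1`, is the next member. Compared with compound 2 the change is fluoro in place of chloro on an aromatic carbon. Going by the values given here, no measured pair shows a chloro giving way to a fluoro, so the single step from compound 1 to compound 2 bears on it only indirectly: it shows that a small change at this position moves the number by a modest amount, not a large one. Swapping one halogen for a smaller one is expected to produce, at most, a shift of similar size or none beyond the scatter, as a 1.0-fold lower number from compound 2 to compound 3 (0.02 log units; within the scatter). Compound 3 is therefore estimated at 65000 nM, with a likely range from 25000 nM to 170000 nM.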

Compound 3, half-maximal inhibitory concentration: 83800 nM
The estimate for compound 3 lay 1.3-fold (0.11 log units) below the measured number, and the stated range covers the measured number.
By their numbers in this assay, from the lowest: compound 1; then compounds 2 and 3 (each within the scatter of the next).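

In this assay, the change from 4-chlorophenyl to 4-fluorophenyl gives a 1.2-fold higher number from compound 2 to compound 3 (0.09 log units; within the scatter), so at this position the two halogens cannot be told apart, even though fluorine is the smaller atom of the pair. The nitrile now stands apart from both halogens rather than from chloro alone: fluoro in place of cyano gives a 3.4-fold higher number from compound 1 to compound 3 (0.54 log units; beyond the scatter), a modest step of the same kind as a 2.8-fold higher number from compound 1 to compound 2 (0.45 log units; beyond the scatter), and so the earlier gap was not special to chloro. No measurement here explains why the nitrile compound gives the lowest number of the three.

The compounds shown leave open how other groups at this position would compare, for example an amine, a methoxy group or a carboxylic acid, and whether any of them would move the number further than the nitrile does. They also leave open whether the small gap between the nitrile and the halogens would hold if the sulfonamide on the other ring were changed, since that end of the shared core stays the same throughout.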